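The source may hold more compounds than are shown below. What is called first, only, known or untested is meant among the compounds shown, and "the series" means these compounds.

Measured compounds in a functional assay on FM3A cells (Mus musculus) for inhibition, read by cell counting, with a stated time of 2 days; a lower number here means a stronger inhibitor, a higher number a weaker inhibitor:
Compound 1 `Nc1cccc(-c2cn3nc(-c4cccs4)sc3n2)c1` gives > 250000 nM, which is a limit of the assay and not a number, as recorded in the limit of > 250000 nM in this assay, at which 1 of the 3 values shown sits.
Compound 2 `CCc1ccc(-c2nn3cc(-c4cccc(N)c4)nc3s2)cc1` gives 8200 nM.
Compound 3 `C=C(Br)C(=O)Nc1cccc(-c2cn3nc(-c4ccc(F)cc4)sc3n2)c1` gives 610 nM.

Of the two numbers shown in this assay, compound 3 has the lowest; the nearest is compound 2, whose number is higher by a margin beyond the scatter, while compound 1 contributes only a limit. Within the data shown here, no two measured compounds differ from one another in a single place, so no single-site step has been measured yet.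

Compound 4 `C=C(Br)C(=O)Nc1cccc(-c2cn3nc(-c4ccccc4)sc3n2)c1` is the next compound to be measured in this assay. Against compound 3 the change is hydrogen in place of fluoro on an aromatic carbon of a six-membered aromatic ring of carbon only, para to a large group; read one bond further out, 4-fluorophenyl to phenyl. The rest of the structure is unchanged.

Among the measured compounds shown here, with no measured step bearing on this change, the expected step in this assay, a 1.3-fold higher number from compound 3 to compound 4 (0.12 log units; within the scatter), is one that stays within the scatter, in no firm direction. Compound 4 is therefore estimated to give about 800 nM in this assay, with a range from 300 nM to 2500 nM.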

Compound 4, half-maximal inhibitory concentration: 900 nM
For compound 4 the middle estimate is 1.1-fold (0.05 log units) below the measured one, within the range that was stated.
By their numbers in this assay, from the lowest: compounds 3 and 4 (each within the scatter of the next); then compound 2. At a limit, above all of these: compound 1.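

The series now has its first single-place step in this assay: hydrogen in place of fluoro on an aromatic carbon of a six-membered aromatic ring of carbon only, para to a large group, gives a 1.5-fold higher number from compound 3 to compound 4 (0.17 log units; within the scatter). This step shows that 4-fluorophenyl and phenyl cannot be told apart at this position in this assay, so fluoro is not required for a number in this range on the otherwise unchanged structure. Nothing measured in the series accounts for this match, and the one available note on the data concerns a limit, not this change.

Still open, as far as these compounds go, is whether a group of another kind at this position, such as methoxy, an amine or a carboxylic acid, would give a number beyond the scatter of these two, since fluoro and hydrogen alone say little about the position's wider tolerance. Also open, from the compounds shown here alone, is how the number would respond if the bromoacrylamide group of compound 3 and compound 4 gave way to a plain acetamide on the same structure.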